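Bromo for methoxy: expecting little change in binding

The source may report more compounds than this note shows. Statements on the series, on what has been measured and on what is new or still open speak of the compounds shown alone.

Measured so far:
compound 1 `CCn1c(=O)c2c(nc(COc3ccc(F)cc3)n2C)n(CC)c1=O` — in an assay on brain cells (strain Sprague-Dawley) for displacement of a labelled ligand from adenosine receptor A1 (Rattus norvegicus), read by scintillation counting, with a stated time of 60 min (on this read-out higher numbers stand for weaker inhibition and lower numbers for stronger inhibition), compound 1 gives 1230 nM
compound 2 `CCn1c(=O)c2c(nc(COc3ccc(C)cc3)n2C)n(CC)c1=O` — in this assay compound 2 gives 1420 nM
compound 3 `CCn1c(=O)c2c(nc(COc3ccc(OC)cc3)n2C)n(CC)c1=O` — in this assay compound 3 gives 1220 nM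

The three compounds share one core and differ only in the group carried on an aromatic carbon of the outer six-membered ring. Compound 3 shows the lowest of the three numbers, but the distance to its nearest neighbour, a 1.0-fold lower number from compound 1 to compound 3 (0.00 log units; within the scatter), and to the furthest, a 1.2-fold lower number from compound 2 to compound 3 (0.07 log units; within the scatter), both lie within the scatter, so the three stand together and none can be called stronger or weaker than the others.

Compound 4 `CCn1c(=O)c2c(nc(COc3ccc(Br)cc3)n2C)n(CC)c1=O` has not yet been measured. It differs from compound 3 in one place: bromo in place of methoxy on an aromatic carbon. For the measured compounds named here, no measured step involves bromo. Going by the values given here, the steps that bear on it are the three exchanges of the group at this same place: a 1.2-fold higher number from compound 1 to compound 2 (0.06 log units; within the scatter), a 1.0-fold lower number from compound 1 to compound 3 (0.00 log units; within the scatter) and a 1.2-fold lower number from compound 2 to compound 3 (0.07 log units; within the scatter), each within the scatter. On that basis no step beyond the scatter is expected from compound 3 to compound 4 in this assay, which means an expected 1.1-fold higher number from compound 3 to compound 4 (0.03 log units; within the scatter). Compound 4 is therefore estimated at 1300 nM, with a range from 600 nM to 2800 nM.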

Compound 4, inhibition constant: 264 nM
The estimate for compound 4 lay 4.9-fold (0.69 log units) above the measured number; the whole stated range lies above it.
By their numbers in this assay, from the lowest: compound 4; then compounds 3, 1 and 2 (each within the scatter of the next).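

On this assay this place on the ring is not indifferent to what it carries: fluoro, methyl and methoxy could not be told apart, yet bromo stands clear of all three, with a 4.6-fold lower number from compound 3 to compound 4 (0.66 log units; beyond the scatter) and a 5.4-fold lower number from compound 2 to compound 4 (0.73 log units; beyond the scatter) and a 4.7-fold lower number from compound 1 to compound 4 (0.67 log units; beyond the scatter) all on the same side. For the compounds shown here, the flat picture given by the earlier compounds therefore described those three groups only, not the position itself, and a single exchange of 4-methoxyphenyl for 4-bromophenyl was enough to move the number beyond the usual scatter. Nothing among the data shown accounts for why bromo behaves differently from the other groups.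

Bromo and fluoro are both halogens, yet compound 1 sits with compounds 2 and 3 rather than with compound 4, so the shift cannot be assigned to halogens as a class, and the compounds shown leave open what chloro or iodo would do at this place. They also leave open whether a larger change, such as a trifluoromethyl group, a nitrile, an amine or a carboxylic acid here, would lower the number further, leave it unchanged or raise it.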